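A few compounds are considered here, and "the series" means these few. Any claim that something is new, unique, unknown or untested is made for them only; others in the source may bear on it.

Working notes on the series. Of the compounds shown here, two carry a number so far. Compound 1 `CCCCNc1nc(C(F)(F)F)ccc1CNC(=O)C(C)c1ccc(NS(C)(=O)=O)c(F)c1` and compound 2 `Cc1ccc(CC2CCN(c3nc(C(F)(F)F)ccc3CNC(=O)C(C)c3ccc(NS(C)(=O)=O)c(F)c3)CC2)cc1` share the same core and differ in what sits on the pyridine nitrogen-bearing position. In a functional assay on CHO-K1 cells for antagonist activity at transient receptor potential cation channel subfamily V member 1 (Homo sapiens), read by FLIPR (on this read-out lower numbers stand for stronger inhibition and higher numbers for weaker inhibition), compound 1 gives 293 nM, and in this assay compound 2 gives 17 nM. Compound 2 thus stands lowest of the two, and the gap between compound 1 and compound 2 lies beyond the usual scatter, so compound 2 is the more potent of the pair on these numbers.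

Compound 3 `CCCCOC1CCN(c2nc(C(F)(F)F)ccc2CNC(=O)C(C)c2ccc(NS(C)(=O)=O)c(F)c2)CC1` has not been measured. Relative to compound 2 the change is butoxy in place of 4-methylbenzyl on a saturated ring carbon. The six-membered non-aromatic ring with its nitrogen stays in place; only the group on its saturated ring carbon is exchanged. Going by the values given here, no measured pair shows this exchange, so the direction rests on the two values alone. An expected step from compound 2 to compound 3 of a 3.5-fold higher number from compound 2 to compound 3 (0.55 log units; beyond the scatter) toward a higher number is assumed, as a moderate loss in this assay. Compound 3 is estimated at 60 nM, with a range from 15 nM to 240 nM.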

Compound 3, half-maximal inhibitory concentration: 28.2 nM
For compound 3 the middle estimate is 2.1-fold (0.33 log units) above the measured one; measured number inside the range.
By their numbers in this assay, from the lowest: compounds 2 and 3 (each within the scatter of the next); then compound 1.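

In this assay, butoxy in place of 4-methylbenzyl on the saturated ring carbon gives a 1.7-fold higher number from compound 2 to compound 3 (0.22 log units; within the scatter), so a value in the range of compound 2 does not depend on the six-membered aromatic ring of the 4-methylbenzyl group, and an open chain holding one oxygen serves on this carbon as well. The group of 11 heavy atoms, with its six-membered non-aromatic ring, in place of the group of 5 heavy atoms on the aromatic carbon gives a 10-fold lower number from compound 1 to compound 3 (1.02 log units; beyond the scatter), which shows that the low numbers of the series are not tied to the 4-methylbenzyl group alone. Nothing measured here gives a reason for either step.

The compounds shown leave open what the oxygen of butoxy contributes, and a pentyl chain on the same saturated ring carbon would separate that oxygen from the length of the chain. They also leave open how far this carbon tolerates other kinds of group, such as a hydroxyl, an amine or a carboxylic acid, and whether a benzyloxy group, which joins the oxygen to an aromatic ring, would read differently from either group.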